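The source may hold more compounds than are shown below. What is called first, only, known or untested is meant among the compounds shown, and "the series" means these compounds.

Working notes on the series, all readings taken from an ADME assay on Vero cells (Chlorocebus sabaeus) for cytotoxicity, read by MTT assay, with a stated time of 48 h; on this read-out higher numbers stand for weaker inhibition and lower numbers for stronger inhibition. Compound 1 is `O=C(OC1CCC(CN2CCN(c3cc(=O)c4cc(C(F)(F)F)cc([N+](=O)[O-])c4s3)CC2)CC1)c1ccncc1`, compound 2 is `O=C(OC1CCC(CN2CCN(c3cc(=O)c4cc(C(F)(F)F)cc([N+](=O)[O-])c4s3)CC2)CC1)c1cccc(F)c1`, compound 3 is `CC(=O)NC1CCC(CN2CCN(c3cc(=O)c4cc(C(F)(F)F)cc([N+](=O)[O-])c4s3)CC2)CC1`, and compound 4, not yet measured, is `O=C(OC1CCC(CN2CCN(c3cc(=O)c4cc(C(F)(F)F)cc([N+](=O)[O-])c4s3)CC2)CC1)c1cccs1`.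

Compound 3 gives > 64 ug/mL, which is a limit and not a number. Compound 1 gives > 64 ug/mL, also a limit. Compound 2 gives > 64 ug/mL, again a limit. Compound 3 therefore has no numerical position in the series, only a shared ceiling: the limit of > 64 ug/mL in this assay, at which 3 of the 3 values shown sit.

The change under study is ((thiophen-2-yl)carbonyl)oxy in place of acetamido on a saturated ring carbon. In words, ((thiophen-2-yl)carbonyl)oxy stands in place of acetamido on a saturated ring carbon.

For the measured compounds named here, three measured steps bear on this. The closest are a step that the two limits leave unreadable from compound 1 to compound 3 and a step that the two limits leave unreadable from compound 2 to compound 3, which exchange the same acetamido for or against other carbonyl-bearing groups at that carbon, and a step that the two limits leave unreadable from compound 1 to compound 2 varies the group on the carbonyl carbon. None of the three has a readable size. No step beyond the scatter is expected in this assay in either direction because of the limit of > 64 ug/mL in this assay, at which 3 of the 3 values shown sit. The expected change is a step that the limit leaves unreadable from compound 3 to compound 4, and this is an estimate only. For compound 4 the estimated value is 80 ug/mL, with an expected range from 40 ug/mL to 128 ug/mL, and a further limit is the likeliest report.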

Compound 4, half-maximal inhibitory concentration: > 64 ug/mL
Compound 4 was reported as a limit; the forecaster's own chance of this, stated with the estimate: 85%; the middle value is on the limit's open side.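

In this assay no new step can be read: compound 4 gives a limit, as do compound 1, compound 2 and compound 3, so its steps to all three cannot be read. The compounds shown leave open whether either change, on the saturated ring carbon or on the carbonyl carbon, alters the reading at all, since all share one ceiling: the limit of > 64 ug/mL in this assay, at which 4 of the 4 values shown sit.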